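The source may report more compounds than this note shows. Statements on the series, on what has been measured and on what is new or still open speak of the compounds shown alone.

Measured in a functional assay on DU-145 cells (Homo sapiens) for cytotoxicity, read by XTT assay, with a stated time of 24 h; on this read-out lower numbers stand for stronger inhibition and higher numbers for weaker inhibition:

- Compound 1 `Cc1cc(Cl)c2c(c1O)C(=O)C=CC2=O`: 9300 nM
- Compound 2 `COc1cc(C)c(Cl)c2c1C(=O)C=CC2=O`: 26600 nM
- Compound 3 `CCOc1cc(C)cc2c1C(=O)C=CC2=O`: 15000 nM

Compound 3, at 15000 nM, stands within the usual scatter of both compound 1 and compound 2. The next structure, compound 4 `CCOc1cc(C)c(Cl)c2c1C(=O)C=CC2=O`, is compound 3 with chloro in place of hydrogen on an aromatic carbon, ortho to a methyl group and para to an ethoxy group (chloro in place of hydrogen on an aromatic carbon). Among the compounds with values here, no measured pair differs in one place only, so this change has no direct precedent here. Compound 2, which also carries chloro, gives 26600 nM, still within the scatter of compound 3. In this assay, the expected result is therefore no change beyond the scatter, and the step expected is a 1.3-fold higher number from compound 3 to compound 4 (0.12 log units; within the scatter). The estimate for compound 4 is 20000 nM, with an expected range from 10000 nM to 40000 nM.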

Compound 4, half-maximal inhibitory concentration: 25400 nM
Estimate against measurement, compound 4: 1.3-fold (0.10 log units) below, and the stated range covers the measured number.
By their numbers in this assay, from the lowest: compounds 1, 3, 4 and 2 (each within the scatter of the next, the first and the last beyond it).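

In this assay, chloro in place of hydrogen on this aromatic carbon, ortho to a methyl group and para to an ethoxy group, gives a 1.7-fold higher number from compound 3 to compound 4 (0.23 log units; within the scatter) and so makes no measurable difference here. With chloro in place, methyl in place of hydrogen on the saturated chain carbon bound to an oxygen gives a 1.0-fold lower number from compound 2 to compound 4 (0.02 log units; within the scatter) and also makes no measurable difference. Nothing available explains either result. On these data alone, whether bromo or an amine on this aromatic carbon would give a number beyond the scatter remains open.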